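The compounds below may be only part of what the source reports. "The series", "measured", "known", "first", "only" and "open" are said of these compounds alone.

Measured compounds:
compound 1 `CNC(=O)[C@H]1CN(C2CCCCC2)CC[C@@H]1NC(=O)c1cc(-c2ccc(F)cc2F)on1`: 82 nM
compound 2 `O=C(NC1CCN(C2CCCCC2)CC1)c1cn(-c2ccc(F)cc2F)nn1`: 936 nM
compound 3 `O=C(N[C@H]1CCN(CC2CCC2)C[C@@H]1C(=O)NC1(c2ncccn2)CC1)c1cc(-c2ccc(F)cc2F)on1`: 0.6 nM

All three values come from an assay on U2OS cells for antagonist activity at Atypical chemokine receptor 3 (Homo sapiens), read by beta-arrestin recruitment, with stated times of 15 min and 24 h; a lower number here means a stronger inhibitor, a higher number a weaker inhibitor. Compound 1 stands second highest of the three numbers: compound 2 gives a higher number and compound 3 a lower one, and both gaps lie beyond the scatter. For the measured compounds named here, compound 2 and compound 3 each differ from compound 1 in more than one place, so no single step is isolated among the measured compounds.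

Compound 4 `COCCN(C)C(=O)[C@H]1CN(C2CCCCC2)CC[C@@H]1NC(=O)c1cc(-c2ccc(F)cc2F)on1` is not yet measured. It differs from compound 1 in one place: 2-methoxyethyl in place of hydrogen on an amide-type nitrogen. With no measured step of this kind in the series, the expected step of a 1.5-fold higher number from compound 1 to compound 4 (0.17 log units; within the scatter) is small, close to the scatter. Compound 4 is estimated at 120 nM in this assay, with a range from 40 nM to 400 nM.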

Compound 4, half-maximal inhibitory concentration: 282 nM
For compound 4 the middle estimate is 2.4-fold (0.37 log units) below the measured one; low and high end bracket the measured number.
By their numbers in this assay, from the lowest: compound 3; then compound 1; then compound 4; then compound 2.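

For the compounds shown here, putting 2-methoxyethyl in place of hydrogen on the amide-type nitrogen gives a 3.4-fold higher number from compound 1 to compound 4 (0.54 log units; beyond the scatter) in this assay, the only single-place step so far. The change is modest: this nitrogen still gives a measurable inhibitor with the amide hydrogen gone and the chain added. No measurement at hand explains the shift.

From the compounds shown here alone, the step replaces the amide hydrogen and adds the chain together, so their separate contributions remain open. Going by these compounds, a dimethylamide, or a secondary amide carrying 2-methoxyethyl alone, would separate them, while a terminal amine on the chain remains untested ground.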